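A few compounds are considered here, and "the series" means these few. Any claim that something is new, unique, unknown or untested is made for them only; others in the source may bear on it.

In a functional assay on MDA-MB-231 cells (Homo sapiens) for inhibition, read by sulforhodamine B assay, with a stated time of 72 h (a higher number here means a weaker inhibitor of growth, a lower number a stronger inhibitor of growth), the compounds measured so far gave:

Compound 1 `CCOC(=O)/C=C/c1ccncc1-c1ccc2ccccc2c1`: 8090 nM
Compound 2 `O=C(O)/C=C/c1ccncc1-c1ccc2ccccc2c1`: > 10000 nM, which is a limit of the assay and not a number
Compound 3 `CCOC(=O)/C=C/c1ccncc1-c1ccc2c(ccn2C)c1`: 10200 nM

Compound 1 and compound 2 differ by one change, (hydrogen in place of ethyl on an oxygen next to a carbonyl group), which gave an at least 1.2-fold higher number from compound 1 to compound 2 (0.09 log units; that floor lies within the scatter). That step is bounded by the limit of > 10000 nM in this assay, at which 1 of the 3 values shown sits. Compound 3 has a different core from compound 1; the difference between the two cores is not broken down here. Compound 4 `Cn1ccc2cc(-c3cnccc3/C=C/C(=O)O)ccc21`, not yet measured, stands to compound 3 as compound 2 stands to compound 1: hydrogen in place of ethyl on an oxygen next to a carbonyl group, the same change at the same place. For compound 4 in this assay a step like the earlier one is expected, a 1.5-fold higher number from compound 3 to compound 4 (0.17 log units; within the scatter), because compound 3 already gives 10200 nM and the same change in compound 1 gave an at least 1.2-fold higher number from compound 1 to compound 2 (0.09 log units; that floor lies within the scatter). Compound 4 is therefore estimated at 15000 nM, most likely reported only as a limit.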

Compound 4, concentration for 50% growth inhibition: > 10000 nM
Compound 4: only a limit was reported; the forecaster's own chance of this, stated with the estimate: 70%; the middle value lies beyond the limit too.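

Among these compounds, compound 4 is reported only as a limit and not as a number, so no step from compound 3 to compound 4 can be read: the limit of > 10000 nM in this assay, at which 2 of the 4 values shown sit. The compounds shown leave open how far the change from ethoxycarbonyl to carboxy really moves the number in this assay on either core.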